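Dienone-triazole-coumarin series: loss of a methoxy group

The source may hold more compounds than are shown below. What is called first, only, known or untested is meant among the compounds shown, and "the series" means these compounds.

Compound 1 `COc1cccc(/C=C/C(=O)/C=C/c2ccc(OCc3cn(CCOc4cc(=O)oc5ccccc45)nn3)c(OC)c2)c1` and compound 2 `COc1ccc(/C=C/C(=O)/C=C/c2ccc(OCc3cn(CCOc4cc(=O)oc5ccccc45)nn3)c(OC)c2)cc1OC` share a core, and in a functional assay on PC-3 cells (Homo sapiens) for inhibition, read by sulforhodamine B assay, with a stated time of 48 h, tested at 50 uM (a lower number here means less inhibition of growth, a higher number more inhibition of growth at the concentration tested), compound 1 gives 13% while compound 2 gives 19%. Among the compounds with values here, the single change between them, (hydrogen in place of methoxy on an aromatic carbon), made a step of a number 6 percentage points lower from compound 2 to compound 1 (within the scatter); on this evidence the group has little bearing on the read-out in this assay.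

Compound 3 `COc1ccc(/C=C/C(=O)/C=C/c2ccc(OCc3cn(CCCOc4cc(=O)oc5ccccc45)nn3)c(OC)c2)cc1` carries a different core; the difference between the two cores is not broken down here. In this assay compound 3 was reported as "not active" (no number reported), so no single number stands for it.

Compound 4 `COc1cc(/C=C/C(=O)/C=C/c2ccccc2)ccc1OCc1cn(CCCOc2cc(=O)oc3ccccc23)nn1` is derived from compound 3 by hydrogen in place of methoxy on an aromatic carbon. This is the same kind of change as that from compound 2 to compound 1, but not the same: in compound 2 the place is also ortho to a methoxy group, whereas in compound 3 the place is only para to a large group. Since compound 2 to compound 1 moved within the scatter, and compound 3 itself showed no measurable inhibition of growth, the expectation for compound 4 in this assay is a value low and near that of its parent, with a real chance that it is again reported without a number. The estimate for compound 4 is 10%, between 0% and 25%.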

Compound 4, percent growth inhibition at one concentration: "not active" (no number reported)
The entry for compound 4 holds no number, and the estimate cannot be compared.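

In this assay compound 3 stands as "not active" (no number reported) and compound 4 stands as "not active" (no number reported), so no new step can be read from this pair. Nothing shown here bears on this result. The compounds shown leave open how large any effect of the change from 4-methoxyphenyl to phenyl is on the core of compound 3, since neither compound carries a number.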